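The compounds below may be only part of what the source reports. "The series", "measured", "known", "first", "only" and "open" are said of these compounds alone.

Compound 1 `COc1ccc(C(=O)Nc2nn(-c3ccccc3)c(=O)c3ccccc23)cc1` — 10%
Compound 2 `CC(=O)N(C(C)=O)c1nn(-c2ccccc2)c(=O)c2ccccc12` — 0%
Compound 3 `Nc1nn(-c2ccccc2)c(=O)c2ccccc12` — 8%

In an assay on CHO cells for displacement of a labelled ligand from adenosine receptor A3 (Homo sapiens), tested at 1 uM (on this read-out higher numbers stand for more inhibition at the one concentration tested (going by the name of the read-out) and lower numbers for less inhibition), compound 1 gives 10%, the highest of the three numbers shown, yet all three lie within the usual scatter of one another, so no order among them can be claimed. Compound 4 `Cc1ccccc1NC(=O)Nc1nn(-c2ccccc2)c(=O)c2ccccc12` differs from compound 1 in one place: (2-methylphenyl)amino in place of 4-methoxyphenyl on a carbonyl carbon. Within the data shown here, the only measured step, a number 8 percentage points higher from compound 2 to compound 3 (within the scatter), changes the group on the aromatic carbon rather than on the carbonyl carbon and stays within the scatter, so it bears on the new step only loosely. The three measured compounds give no sign that any change at this position moves the read-out. Compound 4 is therefore expected to show no change at the digits printed from compound 1 to compound 4 (within the scatter), no step beyond the scatter. The estimate for compound 4 is 10%, with a range from 0% to 25%.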

Compound 4, a percentage reported as inhibition, at one concentration (the size of the read-out at that concentration, not a potency): 22%
For compound 4 the middle estimate is 12 percentage points below the measured one, within the range that was stated.
By their numbers in this assay, from the lowest: compounds 2, 3 and 1 (each within the scatter of the next); then compound 4.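

In this assay, (2-methylphenyl)amino in place of 4-methoxyphenyl on the carbonyl carbon gives a number 12 percentage points higher from compound 1 to compound 4 (beyond the scatter), the first step among these compounds beyond the scatter, so the read-out does respond to a change at this position. The entering group brings a hydrogen-bond donor and drops the acceptor, but the data do not tie the step to this difference. Nothing at hand explains the step. Still open, going by these compounds, is whether the amino link or the methyl group carries it; phenylamino or (4-methoxyphenyl)amino on the same carbonyl carbon would separate the two.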